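Methyl on the ring amine nitrogen of compound 1

The compounds below may be only part of what the source reports. "The series", "measured", "known", "first", "only" and "open" are said of these compounds alone.

Measured so far:
compound 1 `BrC1=NOC2(CCCNC2)C1` — 58000 nM
compound 2 `c1ccc(C2=NOC3(C2)CN2CCC3C2)cc1` — 53000 nM
compound 3 `COC1=NOC2(C1)CN1CCC2C1` — 16000 nM

In an assay on cell membranes for displacement of a labelled ligand from Neuronal acetylcholine receptor; alpha4/beta2 (Rattus norvegicus) (a higher number here means a weaker inhibitor, a lower number a stronger inhibitor), compound 1 gives 58000 nM, the highest of the three numbers. Compound 2 gives 53000 nM, which lies within the scatter of compound 1, so no order between the two can be read. Compound 3 gives 16000 nM, a lower number that stands beyond the scatter from compound 1. The three differ in more than one place, so none of these gaps is tied to a single structural change.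

Compound 4 `CN1CCCC2(CC(Br)=NO2)C1` differs from compound 1 in one place only: methyl in place of hydrogen on an amine nitrogen in a ring, in words, methyl in place of hydrogen on an amine nitrogen in a ring. Among the compounds with values here, no pair of measured compounds shows this change, so its size cannot be read from the series. The expectation for compound 4 is therefore a step of a 1.2-fold lower number from compound 1 to compound 4 (0.06 log units; within the scatter), not beyond the scatter, in either direction. Compound 4 is estimated at 50000 nM, expected between 15000 nM and 160000 nM.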

Compound 4, inhibition constant: 44000 nM
Compound 4: the middle estimate sits 1.1-fold (0.06 log units) above what was measured, and the stated range covers the measured number.
By their numbers in this assay, from the lowest: compound 3; then compounds 4, 2 and 1 (each within the scatter of the next).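

In this assay the series now has its first comparison of compounds differing in one place: methyl in place of hydrogen on an amine nitrogen in a ring gives a 1.3-fold lower number from compound 1 to compound 4 (0.12 log units; within the scatter) and so stays within the scatter. At this position, hydrogen and methyl therefore cannot be told apart in this assay, and both compounds remain in the same range of numbers. No measurement shown gives a reason for this result.

From the compounds shown here alone, whether a longer chain or a larger group on this nitrogen, such as ethyl or benzyl, would also leave the number within the scatter remains open. The lower number of compound 3 also remains untied to any single structural change.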